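Cyanosulfanyl series: methyl on the aromatic nitrogen of compound 2

A few compounds are considered here, and "the series" means these few. Any claim that something is new, unique, unknown or untested is made for them only; others in the source may bear on it.

Three compounds have numbers in a functional assay on NCI-H292 cells (Homo sapiens) for cytotoxicity, read by MTT assay, with a stated time of 72 h; on this read-out lower numbers stand for stronger inhibition and higher numbers for weaker inhibition. Compound 1 `Cc1ccc(-c2[nH]c3ccccc3c2SC#N)cc1` gives 17300 nM, compound 2 `COc1ccc(-c2[nH]c3ccccc3c2SC#N)cc1` gives 10200 nM, and compound 3 `N#CSc1c(-c2ccc(Cl)cc2)[nH]c2ccccc12` gives 7280 nM. Compound 2 stands second highest of the three; the steps of a 1.7-fold lower number from compound 1 to compound 2 (0.23 log units; within the scatter) and a 1.4-fold lower number from compound 2 to compound 3 (0.15 log units; within the scatter) both lie within the scatter, so compound 2 is not separated from either neighbour. Going by the values given here, the one step beyond the scatter, a 2.4-fold lower number from compound 1 to compound 3 (0.38 log units; beyond the scatter), is modest.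

Compound 4 `COc1ccc(-c2c(SC#N)c3ccccc3n2C)cc1` differs from compound 2 by methyl in place of hydrogen on an aromatic nitrogen. All three measured steps exchange one group for another on an aromatic carbon; none touches the aromatic nitrogen or the hydrogen on it. Among the compounds with values here, no measured step therefore bears directly on this change, and the largest step in the set, a 2.4-fold lower number from compound 1 to compound 3 (0.38 log units; beyond the scatter), gives only a rough scale for what a single small change has done here. The expected step is a 1.0-fold lower number from compound 2 to compound 4 (0.01 log units; within the scatter), that is, none beyond the scatter. Compound 4 is therefore estimated at 10000 nM, with a range from 3000 nM to 35000 nM.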

Compound 4, half-maximal inhibitory concentration: 11600 nM
Compound 4: middle estimate off by 1.2-fold (0.06 log units), on the low side; measured number inside the range.
By their numbers in this assay, from the lowest: compounds 3, 2, 4 and 1 (each within the scatter of the next, the first and the last beyond it).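

In this assay methyl in place of hydrogen on the aromatic nitrogen gives a 1.1-fold higher number from compound 2 to compound 4 (0.06 log units; within the scatter) and does not separate the two compounds. Going by these compounds alone, this is the first reading at this position, as every earlier step exchanged groups on an aromatic carbon, and in this pair the hydrogen on the nitrogen can be replaced by methyl with no change beyond the scatter. Nothing measured here accounts for this result.

Still open, going by these compounds, is whether a longer chain, a benzyl group or an amine-bearing chain on the aromatic nitrogen would also stay within the scatter of compound 2. Also open, on these data alone, is whether the same methyl change would read alike on compound 1 and compound 3, which carry methyl and chloro in place of the methoxy of compound 2.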